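Swapping 4-bromophenyl for 3,4-dichlorophenyl

A few compounds are considered here, and "the series" means these few. Any claim that something is new, unique, unknown or untested is made for them only; others in the source may bear on it.

In a functional assay on MCF7 cells (Homo sapiens) for antiproliferative activity, read by MTT assay (on this read-out higher numbers stand for weaker inhibition and lower numbers for stronger inhibition), compound 1 `COc1ccc(-c2ccnc(Nc3ccc([N+](=O)[O-])cc3)n2)cc1` gives 770 nM and compound 2 `O=[N+]([O-])c1ccc(Nc2nccc(-c3ccc(Br)cc3)n2)cc1` gives 681000 nM, the higher of these two numbers and so the weaker inhibition. Compound 3 `Cc1ccc(-c2ccnc(Nc3ccc(Cl)cc3Cl)n2)cc1` is reported only as a limit, > 1000000 nM. For the measured compounds named here, the single measured step, an 880-fold higher number from compound 1 to compound 2 (2.95 log units; beyond the scatter), is large and puts bromo in place of methoxy on an aromatic carbon. Compound 4 `O=[N+]([O-])c1ccc(Nc2nccc(-c3ccc(Cl)c(Cl)c3)n2)cc1` has not yet been measured. It differs from compound 2 in one place, with 3,4-dichlorophenyl in place of 4-bromophenyl on an aromatic carbon of a six-membered aromatic ring with 2 nitrogen (3,4-dichlorophenyl in place of 4-bromophenyl on an aromatic carbon). Compound 2 already lacks the methoxy of compound 1, and halogen stays on this ring in compound 4, so a repeat of the large step of an 880-fold higher number from compound 1 to compound 2 (2.95 log units; beyond the scatter) is not expected. The estimated step, a 1.4-fold lower number from compound 2 to compound 4 (0.13 log units; within the scatter), is expected to stay within the scatter, with no firm direction. Compound 4 is therefore estimated at 500000 nM, with an expected range from 80000 nM to 1000000 nM.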

Compound 4, half-maximal inhibitory concentration: 3510 nM
Beside the measured number, compound 4's estimate is 140-fold (2.15 log units) above it; measured number below the stated range.
By their numbers in this assay, from the lowest: compound 1; then compound 4; then compound 2. At a limit, above all of these: compound 3.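

Halogen on this phenyl ring does not by itself go with weak inhibition in this assay: 3,4-dichlorophenyl in place of 4-bromophenyl gives a 190-fold lower number from compound 2 to compound 4 (2.29 log units; beyond the scatter). Against the methoxy group, the same change gives only a 4.6-fold higher number from compound 1 to compound 4 (0.66 log units; beyond the scatter), so compound 4 regains most of the ground lost with bromo, and compound 2 and compound 4 go against any rule that treats halogen-bearing rings at this position alike. No measured property shown here accounts for so large a difference between these two halogen-bearing groups.

Going by these compounds, it remains open whether 4-chlorophenyl or 3-chlorophenyl would fall nearer to compound 2 or to compound 4 in this assay. On these data alone, it is also open how an amine or a carboxylic acid on this phenyl ring would compare with methoxy and the halogens.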